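Cytotoxicity of a Pyridinyl-Thiazole Amide Series on Vero Cells

The source may report more compounds than this note shows. Statements on the series, on what has been measured and on what is new or still open speak of the compounds shown alone.

Measured compounds:
compound 1 `Cc1cccc(C(=O)Nc2nc(-c3ccccn3)cs2)c1`: 4100 nM
compound 2 `CC(=O)c1cccc(C(=O)Nc2nc(-c3ccccn3)cs2)c1`: 1500 nM
compound 3 `O=C(Nc1nc(-c2ccccn2)cs1)c1c(F)cccc1F`: 3200 nM

In an ADME assay on Vero cells (Chlorocebus sabaeus) for cytotoxicity, read by MTT assay, with a stated time of 72 h (on this read-out lower numbers stand for an effect already at smaller amounts and higher numbers for an effect only at larger amounts of compound), compound 1 stands at the highest of the three numbers. Compound 3, which carries a 2,6-difluorophenyl group on the shared core, gives 3200 nM in this assay, a number within the usual scatter of compound 1, so the two cannot be ordered. Among the compounds with values here, compound 2 gives 1500 nM in this assay, and the single step that differs in one place, a 2.7-fold lower number from compound 1 to compound 2 (0.44 log units; beyond the scatter), is the only measured step in this set that exceeds the scatter.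

Compound 4 `O=C(Nc1nc(-c2ccccn2)cs1)c1cccnc1Cl` has not yet been measured. It differs from compound 1 by 2-chloropyridin-3-yl in place of 3-methylphenyl on a carbonyl carbon. This change again replaces the aryl group on the carbonyl carbon, so the step from compound 1 to compound 2 is the one that bears on it, and it was modest. Within the data shown here, no measured step involves a pyridinyl or chloro group on this ring, so the direction cannot be read from the data. Given that compound 3 also altered this ring without moving beyond the scatter, a small step at most is expected in this assay, a 1.4-fold lower number from compound 1 to compound 4 (0.14 log units; within the scatter). Compound 4 is therefore estimated at 3000 nM, in the range 1200 nM to 7500 nM.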

Compound 4, half-maximal effective concentration: 1900 nM
The estimate for compound 4 lay 1.6-fold (0.20 log units) above the measured number; the measured number falls inside the stated range.
By their numbers in this assay, from the lowest: compounds 2, 4, 3 and 1 (each within the scatter of the next, the first and the last beyond it).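

Swapping the whole aryl group on the carbonyl carbon moves the number beyond the scatter in this assay, with a 2.2-fold lower number from compound 1 to compound 4 (0.33 log units; beyond the scatter), so this position responds to more than the substituent change seen earlier, where acetyl replaced methyl. Here 3-methylphenyl leaves and 2-chloropyridin-3-yl enters, with the same number of heavy atoms but a ring hetero atom and a hydrogen-bond acceptor that 3-methylphenyl lacks, and the number falls in the same direction as with compound 2, while compound 3 goes against this trend by staying within the scatter of compound 1. Nothing at hand accounts for why this change lowers the number.

The ring nitrogen and the chlorine enter together in compound 4, so the compounds shown cannot assign the step to either one, which a plain pyridin-3-yl or a 2-chlorophenyl group on the same carbonyl carbon could begin to separate. They also leave open how this position would respond to an aryl group bearing an amine or a carboxylic acid.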